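Sulfonamide series: butyl in place of cyclohexyl in compound 4

This account rests on a few compounds, and the source may have more. Where it says the series, first, only, none or still open, it means among the compounds named here.

Values in a toxicity assay on Vero cells (Chlorocebus sabaeus) for cytotoxicity, read by MTT assay (on this read-out lower numbers stand for stronger inhibition and higher numbers for weaker inhibition), for the measured compounds:
compound 1 `COC(=O)NC(=O)c1ccsc1NC(=O)c1ccc(S(=O)(=O)N2CCC2)cc1` gives 17.5 ug/mL
compound 2 `COC(=O)NC(=O)c1ccsc1NC(=O)c1ccc(S(=O)(=O)N2CCC(OC)CC2)cc1` gives 18 ug/mL
compound 3 `COC(=O)NC(=O)c1ccsc1NC(=O)c1ccc(S(=O)(=O)NC2CCCCC2)cc1` gives > 64 ug/mL (a limit, not a number)

Compound 3 has a limit and no number, and it sits at the limit of > 64 ug/mL in this assay, at which 1 of the 3 values shown sits.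

Compound 4 `CCCCNS(=O)(=O)c1ccc(C(=O)Nc2sccc2C(=O)NC(=O)OC)cc1` carries butyl in place of cyclohexyl on a sulfonamide nitrogen. Going by the values given here, no measured step makes this change directly. Among the compounds with values here, the steps that bear on it are the two ending in cyclohexylamino, an at least 3.6-fold higher number from compound 1 to compound 3 (0.56 log units; beyond the scatter) and an at least 3.5-fold higher number from compound 2 to compound 3 (0.55 log units; beyond the scatter), both beyond the scatter. Exchanging the other two groups gave a 1.0-fold higher number from compound 1 to compound 2 (0.01 log units; within the scatter), within the scatter. Cyclohexylamino is the closest measured group to butylamino, so compound 4 is expected to lie nearer compound 3 than the other two. The expected change is an at least 1.3-fold lower number from compound 3 to compound 4 (0.12 log units; that floor lies within the scatter), a small move towards a lower number that may not clear the scatter, and a second limit in this assay would be no surprise. For compound 4 the estimate is 48 ug/mL, with an expected range from 20 ug/mL to 90 ug/mL.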

Compound 4, half-maximal inhibitory concentration: 29.5 ug/mL
For compound 4 the middle estimate is 1.6-fold (0.21 log units) above the measured one; the measured number falls inside the stated range.
By their numbers in this assay, from the lowest: compounds 1, 2 and 4 (each within the scatter of the next). At a limit, above all of these: compound 3.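

In this assay, butyl in place of cyclohexyl on a sulfonamide nitrogen gives an at least 2.1-fold lower number from compound 3 to compound 4 (0.33 log units; beyond the scatter), so an alkylamino group on the sulfonyl sulfur does not by itself hold the number at the limit. Compound 3 stands at a limit and not at a number: the limit of > 64 ug/mL in this assay, at which 1 of the 4 values shown sits. Butylamino does not separate from the two ring groups, with a 1.6-fold higher number from compound 2 to compound 4 (0.21 log units; within the scatter) and a 1.7-fold higher number from compound 1 to compound 4 (0.23 log units; within the scatter), which leaves cyclohexylamino as the only group shown that stands apart.

As far as these compounds go, the true size of the step from cyclohexyl to butyl stays open, with only a floor for it. Also open, from the compounds shown here alone, is whether methyl, a longer chain such as octyl, or a chain ending in a carboxylic acid on the sulfonamide nitrogen would stay level with compound 4 or stand with compound 3.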